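The source may report more compounds than this note shows. Statements on the series, on what has been measured and on what is new or still open speak of the compounds shown alone.

Going by the values given here, compound 2 `Oc1ccccc1/C=N/c1cc2ccccc2nc1-c1ccccc1F` has one of the two numbers measured so far: in an ADME assay on L02 cells (Homo sapiens) for cytotoxicity, read by MTT assay, with a stated time of 48 h (a higher number here means a weaker inhibitor, a lower number a stronger inhibitor), compound 2 gives 31900 nM. The other measured compound, compound 1 `COc1ccc(/C=N/c2cc3ccccc3nc2-c2ccccc2F)c(O)c1`, gives 38200 nM in this assay, and the step of a 1.2-fold lower number from compound 1 to compound 2 (0.08 log units; within the scatter) is within the scatter. Compound 3 `Oc1cccc(/C=N/c2cc3ccccc3nc2-c2ccccc2F)c1O` differs from compound 2 by hydroxy in place of hydrogen on an aromatic carbon. Among the compounds with values here, no measured step adds a hydroxy group; the only step known, the removal of a methoxy group from compound 1 to compound 2, stayed within the scatter, so no change beyond the scatter is expected here. Compound 3 is therefore estimated to give 30000 nM, between 15000 nM and 60000 nM, meaning an expected step of a 1.1-fold lower number from compound 2 to compound 3 (0.03 log units; within the scatter).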

Compound 3, half-maximal inhibitory concentration: 34000 nM
The estimate for compound 3 lay 1.1-fold (0.05 log units) below the measured number; the measured number falls inside the stated range.
By their numbers in this assay, from the lowest: compounds 2, 3 and 1 (each within the scatter of the next).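

In this assay, hydroxy placed on the aromatic carbon ortho to a hydroxy group and meta to a large group gives a 1.1-fold higher number from compound 2 to compound 3 (0.03 log units; within the scatter), so adding a group at this position, not only removing one elsewhere, fails to separate the compounds. Putting 2,3-dihydroxyphenyl in place of 2-hydroxy-4-methoxyphenyl gives a 1.1-fold lower number from compound 1 to compound 3 (0.05 log units; within the scatter), so all three compounds remain within the scatter of one another. Nothing available offers a reason for this. As far as these compounds go, whether an amine or a carboxylic acid at this position would produce a step beyond the scatter remains open.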